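Alkoxy variation on a nitroaryl sulfonamide series

A few compounds are considered here, and "the series" means these few. Any claim that something is new, unique, unknown or untested is made for them only; others in the source may bear on it.

Measured compounds:
compound 1, `CN(c1ccc([N+](=O)[O-])cc1OC1CCCCC1)S(C)(=O)=O`, 470 nM
compound 2, `CN(c1ccc([N+](=O)[O-])cc1OCC1CCCCC1)S(C)(=O)=O`, 960 nM
compound 3, `CN(c1ccc([N+](=O)[O-])cc1OC1CCCC1)S(C)(=O)=O`, 440 nM

The read-out is an assay on SK-BR-3 cells for inhibition of Aromatase (Homo sapiens); a higher number here means a weaker inhibitor, a lower number a stronger inhibitor. Compound 3 holds the lowest of the three numbers in this assay; its gap to compound 1 is within the scatter (a 1.1-fold lower number from compound 1 to compound 3 (0.03 log units; within the scatter)), while compound 2 stands above it (a 2.2-fold lower number from compound 2 to compound 3 (0.34 log units; beyond the scatter)). Compound 4, `CCCCCCOc1cc([N+](=O)[O-])ccc1N(C)S(C)(=O)=O`, carries hexyl in place of cyclopentyl on an oxygen on an aromatic ring. For the measured compounds named here, two measured steps bear on this: the added carbon in a 2.0-fold higher number from compound 1 to compound 2 (0.31 log units; beyond the scatter) raised the number modestly, and a 2.2-fold lower number from compound 2 to compound 3 (0.34 log units; beyond the scatter) lowered it by a similar margin. Replacing the ring with a hexyl chain is therefore expected to give a modest step upward, a 2.0-fold higher number from compound 3 to compound 4 (0.31 log units; beyond the scatter). Compound 4 is estimated at 900 nM, within a range of 400 nM to 2000 nM.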

Compound 4, half-maximal inhibitory concentration: 4490 nM
Beside the measured number, compound 4's estimate is 5.0-fold (0.70 log units) below it, and the stated range ends below it.
By their numbers in this assay, from the lowest: compounds 3 and 1 (each within the scatter of the next); then compound 2; then compound 4.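

In this assay, replacing a ring on this oxygen with an open chain outweighs every change among the cyclic groups: a 10-fold higher number from compound 3 to compound 4 (1.01 log units; beyond the scatter), and a 9.6-fold higher number from compound 1 to compound 4 (0.98 log units; beyond the scatter). The hexyl chain also stands above the cyclohexylmethyl group, with a 4.7-fold higher number from compound 2 to compound 4 (0.67 log units; beyond the scatter), so across these four compounds the lower numbers go with a ring on this oxygen, not with carbon count alone. No evidence at hand accounts for this jump. Still open, from the compounds shown here alone, is whether shorter or branched open chains, such as butyl or isopropyl, track with hexyl or with the cyclic groups.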